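The source may report more compounds than this note shows. Statements on the series, on what has been measured and on what is new or still open speak of the compounds shown alone.

Measured compounds:
Compound 1 `NC(=S)N1CCc2c(OCCCCCOc3ccc(Cl)cc3)cccc21` gives in an ADME assay on Huh-7 cells (Homo sapiens) for cytotoxicity (on this read-out lower numbers stand for higher toxicity in this test and higher numbers for lower toxicity in this test), only a limit of the assay, > 50000 nM.
Compound 2 `N#Cc1ccc(C(=O)NC(=S)N2CCc3c(OCCCCCOc4ccc(Cl)cc4)cccc32)cc1` gives in this assay likewise only a limit, > 50000 nM.
Compound 3 `O=C(NC(=S)N1CCc2c(OCCCCCOc3ccc(Cl)cc3)cccc21)c1ccc(C(F)(F)F)cc1` gives in this assay a number, 32700 nM.

Compound 2 thus stands at the assay limit, where two of the three values sit (the limit of > 50000 nM in this assay, at which 2 of the 3 values shown sit); no number is known for it, and the step from compound 1 is unreadable a step that the two limits leave unreadable from compound 1 to compound 2. The unmeasured compound 4 `O=C(NC(=S)N1CCc2c(OCCCCCOc3ccc(Cl)cc3)cccc21)c1ccc2ccccc2c1` differs from compound 2 in one place: naphthalen-2-yl in place of 4-cyanophenyl on a carbonyl carbon. For the measured compounds named here, the only measured step that touches the same region of the molecule is the exchange on the aromatic carbon, an at least 1.5-fold lower number from compound 2 to compound 3 (0.18 log units; that floor lies within the scatter), a floor that lies within the scatter, and the parallel step from the unsubstituted thiourea, an at least 1.5-fold lower number from compound 1 to compound 3 (0.18 log units; that floor lies within the scatter), is of the same kind. Every shown change at the carbonyl carbon has therefore left the read-out at or near the limit. For compound 4 the expectation in this assay is a value at the limit or just below it, an estimated step of an at least 1.2-fold lower number from compound 2 to compound 4 (0.09 log units; that floor lies within the scatter) that may again be reported only as a limit. Compound 4 is estimated at 40000 nM, within 18000 nM to 100000 nM.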

Compound 4, half-maximal cytotoxic concentration: > 50000 nM
Compound 4: only a limit was reported; the forecaster's own chance of this, stated with the estimate: 45%; middle value at least 1.2-fold (0.09 log units) from the limit.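

Notes on the series: in this assay compound 4 gives > 50000 nM, which is a limit of the assay, so naphthalen-2-yl on the carbonyl carbon adds a second ring system to the groups tried there without giving a number. Naphthalen-2-yl in place of 4-(trifluoromethyl)phenyl gives an at least 1.5-fold higher number from compound 3 to compound 4 (0.18 log units; that floor lies within the scatter); only this floor is known, and it does not establish a real difference between the two groups. The steps that join compound 4 to compound 1 and to compound 2 cannot be read, because both ends of each step sit at the same limit: the limit of > 50000 nM in this assay, at which 3 of the 4 values shown sit.

For the compounds shown here, compound 3 remains the only compound with a number in this assay, so the true size of every change on the carbonyl carbon stays unknown, and no trend across these groups can be drawn. The compounds shown leave open what a carboxylic acid or an amine in place of the nitrile on the aromatic carbon would do to this read-out.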